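A chloro group on compound 1

The compounds below may be only part of what the source reports. "The series", "measured", "known", "first", "only" and "open" are said of these compounds alone.

In a functional assay (aorta) for inhibition, with Rattus norvegicus as the target (a lower number here means that less compound is needed, a higher number that more compound is needed for the effect), compound 1 `O=C1C=C(Nc2ccccc2)C(=O)c2cnccc21` gives 439 nM. That value lies within the scatter of compound 2 `O=C1C=C(Nc2cccc(F)c2)C(=O)c2cnccc21` at 562 nM and of compound 3 `O=C1C=C(Nc2ccc(F)cc2F)C(=O)c2cnccc21` at 430 nM, so the three sit at one level. Compound 4 `O=C1C=C(Nc2ccc(Cl)cc2)C(=O)c2cnccc21` is the unmeasured analogue of compound 1: chloro in place of hydrogen on an aromatic carbon, with chloro in place of hydrogen on an aromatic carbon, para to a large group. The nearest measured single change is fluoro in place of hydrogen, a 1.3-fold higher number from compound 1 to compound 2 (0.11 log units; within the scatter). Among the compounds with values here, no chloro compound has been measured, so that step is only an indirect guide. A change beyond the scatter is therefore not expected in this assay. The expected step is a 1.0-fold higher number from compound 1 to compound 4 (0.01 log units; within the scatter). For compound 4 the estimated value is 450 nM, with an expected range of 200 nM to 1000 nM.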

Compound 4, half-maximal effective concentration: 190 nM
For compound 4 the middle estimate is 2.4-fold (0.37 log units) above the measured one, outside the stated range (below it).
By their numbers in this assay, from the lowest: compound 4; then compounds 3, 1 and 2 (each within the scatter of the next).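

In this assay, chloro in place of hydrogen on an aromatic carbon, para to a large group, gives a 2.3-fold lower number from compound 1 to compound 4 (0.36 log units; beyond the scatter) and is the only single change shown that moves the number beyond the scatter, whereas the fluoro change gives a 1.3-fold higher number from compound 1 to compound 2 (0.11 log units; within the scatter) and does not. This position therefore responds to chloro, and the lower number shows that the added atom is tolerated there. Nothing measured here explains this step.

Going by these compounds, it remains open whether the shift belongs to chloro itself or to this position. A bromo, methyl or amine group on the same carbon would help to separate the two.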